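From carboxymethyl to (4-hydroxypiperidin-1-yl)carbonyl on compound 1

A few compounds are considered here, and "the series" means these few. Any claim that something is new, unique, unknown or untested is made for them only; others in the source may bear on it.

In an ADME assay on microsomes from liver (Mus musculus) for metabolic stability, read by LC-MS, using NADPH, with a stated time of 60 min, tested at 1 uM (on this read-out higher numbers stand for a longer-lived compound and lower numbers for a shorter-lived compound), compound 1 `O=C(O)CCC1Cc2ccc(-c3cc(F)cc(OC(F)F)c3)cc2N1S(=O)(=O)c1cccc(C(F)(F)F)c1` gives 1.02 h as its half-life. In this assay compound 2 `O=C(O)CCC1CN(S(=O)(=O)c2cccc(C(F)(F)F)c2)c2cc(-c3cc(F)cc(OC(F)F)c3)ccc21` gives 0.408 h as its half-life, so compound 1 stands at the higher of the two numbers, and the gap between them lies beyond the usual scatter. Compound 3 `O=C(CC1Cc2ccc(-c3cc(F)cc(OC(F)F)c3)cc2N1S(=O)(=O)c1cccc(C(F)(F)F)c1)N1CCC(O)CC1` has not yet been measured. It keeps the core of compound 1 and carries (4-hydroxypiperidin-1-yl)carbonyl in place of carboxymethyl on a saturated chain carbon bound to a saturated ring carbon. For the measured compounds named here, no measured pair of compounds shows this change, so the direction is a judgement and not a reading. The step expected in this assay is a moderate fall beyond the usual scatter (a 2.3-fold lower number from compound 1 to compound 3 (0.36 log units; beyond the scatter)). In this assay the expected half-life of compound 3 is 0.45 h with a likely range of 0.15 h to 1.4 h around that estimate.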

Compound 3, half-life: 0.0117 h
Compound 3: the middle estimate sits 38-fold (1.59 log units) above what was measured; the whole stated range lies above it.
By their numbers in this assay, from the lowest: compound 3; then compound 2; then compound 1.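

In this assay the change from carboxymethyl to (4-hydroxypiperidin-1-yl)carbonyl on a saturated chain carbon bound to a saturated ring carbon gives an 87-fold lower number from compound 1 to compound 3 (1.94 log units; beyond the scatter) as a large step. Both earlier compounds carry carboxymethyl, so they could not show that the half-life depends so strongly on the group at this place. Nothing measured here explains why the half-life falls so far.

The change swaps several features at once, so the compounds shown leave open whether the loss comes with the carbonyl link to the ring nitrogen, the piperidine ring or its hydroxyl group. A plain piperidine amide without the hydroxyl, a morpholine amide or a tetrazole at this place would help to separate these possibilities.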